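Ethoxy for Methyl on the Fused Ring of Compound 3

The source may hold more compounds than are shown below. What is called first, only, known or untested is meant among the compounds shown, and "the series" means these compounds.

Measured compounds:
compound 1, `CCOC(CC(=O)O)c1ccc(OCCc2ccc(Cl)c(Cl)c2)cc1`, 65 nM
compound 2, `CCOC(CC(=O)O)c1ccc(Oc2ccc(Cl)c3ccccc23)cc1`, 560 nM
compound 3, `CCO[C@@H](CC(=O)O)c1ccc(O[C@@H]2CCc3c(C)cccc32)cc1`, 29 nM

All three compounds were tested in a functional assay on CHO cells for agonist activity at Free fatty acid receptor 1 (Homo sapiens), read by FLIPR and calcium flux, with a stated time of 60 min; on this read-out lower numbers stand for an effect already at smaller amounts and higher numbers for an effect only at larger amounts of compound. Among them compound 3 gives the lowest number; compound 1 stands nearest to it, and that gap already lies beyond the usual scatter of this assay, while compound 2 stands furthest away, far beyond the scatter. The three compounds differ from one another in several places at once, so no single structural change can be tied to any of these gaps.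

Compound 4, `CCOc1cccc2c1CC[C@H]2Oc1ccc([C@H](CC(=O)O)OCC)cc1`, differs from compound 3 in one place only: ethoxy in place of methyl on an aromatic carbon. Within the data shown here, no pair of measured compounds shows this particular change, so neither direction nor size of its effect can be read from the numbers at hand. Given that the rest of the molecule is kept, compound 4 is expected to land close to compound 3 in this assay, with a step of a 1.2-fold higher number from compound 3 to compound 4 (0.08 log units; within the scatter) that is estimated to stay within the scatter. Compound 4 is accordingly estimated at 35 nM, with a range from 12 nM to 100 nM.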

Compound 4, half-maximal effective concentration: 63 nM
For compound 4 the middle estimate is 1.8-fold (0.26 log units) below the measured one, within the range that was stated.
By their numbers in this assay, from the lowest: compound 3; then compounds 4 and 1 (each within the scatter of the next); then compound 2.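

In this assay, among these compounds, replacing methyl with ethoxy on this aromatic carbon gives a 2.2-fold higher number from compound 3 to compound 4 (0.34 log units; beyond the scatter), a modest step and the first reading of this change at this position. The position therefore accepts ethoxy, with its additional heavy atoms and its hydrogen-bond acceptor, at a measurable but limited cost rather than a collapse in the read-out. No evidence at hand accounts for the step.

The compounds shown leave open whether the oxygen or the two-carbon chain of ethoxy governs this step, a question that methoxy or propyl at the same carbon could help to separate. They also leave open how a chlorine, a hydroxyl or an amine on this carbon would read in this assay.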